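The source may hold more compounds than are shown below. What is called first, only, known or untested is meant among the compounds shown, and "the series" means these compounds.

Measured in a functional assay on PC-3 cells (Homo sapiens) for inhibition, read by sulforhodamine B assay, with a stated time of 72 h; a lower number here means a stronger inhibitor, a higher number a weaker inhibitor:
- compound 1 `Nc1sc(-c2ccc(Cl)cc2)c(-c2ccc(Cl)cc2)c1C(=O)NC1CCC(O)CC1`: 5670 nM
- compound 2 `CCCCNC(=O)c1c(N)sc(-c2ccc(Cl)cc2)c1-c1ccc(Cl)cc1`: 17800 nM

Compound 2 has the higher of these two numbers, so it is the weaker inhibitor of the pair, and the gap to compound 1 lies beyond the scatter. Compound 3 `Nc1sc(-c2ccc(Cl)cc2)c(-c2ccc(Cl)cc2)c1C(=O)N1CCC(=O)CC1=O` differs from compound 2 in one place, with 2,4-dioxopiperidin-1-yl in place of butylamino on a carbonyl carbon.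

For the measured compounds named here, only one measured step bears on this change: a 3.1-fold higher number from compound 1 to compound 2 (0.50 log units; beyond the scatter). There, butyl took the place of 4-hydroxycyclohexyl on an amide-type nitrogen. Compound 1 carries a six-membered ring at that nitrogen and gives 5670 nM, which suggests that the six-membered ring of compound 3 may also bring a lower number than butyl does. Going by the values given here, this is a weak guide, since no measured compound carries the 2,4-dioxopiperidin-1-yl group. A modest step to a lower number is therefore expected in this assay: a 2.2-fold lower number from compound 2 to compound 3 (0.35 log units; beyond the scatter). The estimate for compound 3 is 8000 nM, with an expected range from 2500 nM to 25000 nM.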

Compound 3, half-maximal inhibitory concentration: 9230 nM
The estimate for compound 3 lay 1.2-fold (0.06 log units) below the measured number, and the stated range covers the measured number.
By their numbers in this assay, from the lowest: compounds 1, 3 and 2 (each within the scatter of the next, the first and the last beyond it).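

In this assay, both new steps stay within the scatter: a 1.9-fold lower number from compound 2 to compound 3 (0.29 log units; within the scatter), and a 1.6-fold higher number from compound 1 to compound 3 (0.21 log units; within the scatter). Compound 3 therefore cannot be told apart from either of the other two compounds, even though those two do differ from each other, with a 3.1-fold higher number from compound 1 to compound 2 (0.50 log units; beyond the scatter). On this carbonyl carbon, butylamino, which has one hydrogen-bond donor, can thus give way to 2,4-dioxopiperidin-1-yl, a six-membered ring with no hydrogen-bond donor and two hydrogen-bond acceptors, with no step beyond the scatter, and no measurement is available that would explain this result.

The compounds shown do not separate the contribution of the ring from that of its two carbonyl groups, a question that plain piperidin-1-yl, with no carbonyl in the ring, could help to answer. They also leave open how the number would respond to a longer chain on the amide nitrogen, or to a carboxylic acid or an amine at the end of such a chain.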